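This account rests on a few compounds, and the source may have more. Where it says the series, first, only, none or still open, it means among the compounds named here.

Compound 1, `CSc1nc(-c2ccco2)c(C#N)c(=O)n1C`, was tested in a functional assay, with a stated time of 20 min (on this read-out lower numbers stand for stronger inhibition and higher numbers for weaker inhibition), where compound 1 gives 68 ug/mL. Compound 2, `CSc1nc(-c2cccs2)c(C#N)c(=O)n1C`, differs from compound 1 by a single change, (thiophen-2-yl in place of furan-2-yl on an aromatic carbon), and in this assay compound 2 gives 71 ug/mL. That change made a step of a 1.0-fold higher number from compound 1 to compound 2 (0.02 log units; within the scatter).

Compound 3, `CCOC(=O)c1cnn(-c2nc(-c3ccco3)c(C#N)c(=O)n2C)c1N`, has a different core; how the two cores differ is not broken down here. In this assay compound 3 gives 91 ug/mL, and its values against compound 1 and compound 2 all lie within the scatter of one another.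

Compound 4, `CCOC(=O)c1cnn(-c2nc(-c3cccs3)c(C#N)c(=O)n2C)c1N`, is not yet measured. It relates to compound 3 by thiophen-2-yl in place of furan-2-yl on an aromatic carbon. Among the measured compounds shown here, this is the same kind of change as the one between compound 1 and compound 2, though the surroundings differ: in compound 3 the place is meta to a large group, whereas in compound 1 it is meta to a methylsulfanyl group (2 heavy atoms). Because the earlier change gave a 1.0-fold higher number from compound 1 to compound 2 (0.02 log units; within the scatter), a step of about a 1.0-fold higher number from compound 3 to compound 4 (0.00 log units; within the scatter) is expected here. Compound 4 is therefore estimated to give 92 ug/mL in this assay, with the range 55 ug/mL to 160 ug/mL expected.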

Compound 4, half-maximal inhibitory concentration: 79 ug/mL
Beside the measured number, compound 4's estimate is 1.2-fold (0.07 log units) above it, within the range that was stated.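

In this assay, thiophen-2-yl in place of furan-2-yl makes a 1.2-fold lower number from compound 3 to compound 4 (0.06 log units; within the scatter). Set beside the same swap on the core of compound 1, the two steps agree: the same change on two cores in this assay, a 1.0-fold higher number (0.02 log units; within the scatter) from compound 1 to compound 2 and a 1.2-fold lower number (0.06 log units; within the scatter) from compound 3 to compound 4, 1.2-fold (0.08 log units) apart, within the scatter of two such steps. So in these two pairs the swap carries from one core to the other with no readable effect on the number, but two steps inside the scatter show only that no effect was detected, not that the two rings are interchangeable on every core, and a small real difference could still be hidden in either pair.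

On these data alone, only furan-2-yl and thiophen-2-yl appear at this place, so it remains open whether a different kind of group there, such as a phenyl ring, an amine or a longer alkyl chain, would move the number beyond the scatter. Also open, as far as these compounds go, is whether an ethyl group or a longer chain in place of the methyl group would leave the number unmoved.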